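The source may hold more compounds than are shown below. What is called first, only, known or untested is meant among the compounds shown, and "the series" means these compounds.

Measured compounds:
Compound 1 `CC/C=C\C(=O)Nc1cc(Nc2nc3c(c(-c4cn(C)c5ccc(F)cc45)n2)CSCC3)c(OC)cc1N(C)CCN(C)C` — 1450 nM
Compound 2 `C=C(Cl)C(=O)Nc1cc(Nc2nc3c(c(-c4cn(C)c5ccccc45)n2)CSCC3)c(OC)cc1N(C)CCN(C)C` — 716 nM

The two measured compounds share a core and differ in two places at once, in the group on the amide carbonyl and in the indole substituent, so no single-change step can be read between them. In a functional assay on A549 cells (Homo sapiens) for inhibition, read by MTT assay, with a stated time of 72 h (a lower number here means a stronger inhibitor, a higher number a weaker inhibitor), compound 2 gives 716 nM, the lowest of the two numbers. Its nearest neighbour is compound 1, which in this assay gives 1450 nM, a higher number by a margin that lies beyond the usual scatter.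

Compound 3 `CC/C=C\C(=O)Nc1cc(Nc2nc3c(c(-c4cn(C)c5ccccc45)n2)CSCC3)c(OC)cc1N(C)CCN(C)C` has not been measured. It differs from compound 2 in one place: but-1-en-1-yl in place of 1-chloroethenyl on a carbonyl carbon. This carries the but-1-en-1-yl group of compound 1 onto the unsubstituted indole of compound 2. The two measured values do not separate the contribution of the carbonyl substituent from that of the indole change, so the size of the step is uncertain. Compound 3 is expected to give a somewhat higher number than compound 2, with the step of a 1.7-fold higher number from compound 2 to compound 3 (0.22 log units; within the scatter) expected to be modest and not clearly beyond the scatter. The value of compound 3 in this assay is estimated at 1200 nM, with a range from 500 nM to 3000 nM.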

Compound 3, half-maximal inhibitory concentration: 236 nM
Estimate against measurement, compound 3: 5.1-fold (0.71 log units) above; measured number outside the range, below it.
By their numbers in this assay, from the lowest: compound 3; then compound 2; then compound 1.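

In this assay the change from 1-chloroethenyl to but-1-en-1-yl on the carbonyl carbon gives a 3.0-fold lower number from compound 2 to compound 3 (0.48 log units; beyond the scatter) and so shows that, with the rest of the structure held fixed, this position tolerates the loss of the chlorine-bearing group and favours the but-1-en-1-yl group in this pair. The second single change, hydrogen in place of fluoro on an aromatic carbon, gives a 6.1-fold lower number from compound 1 to compound 3 (0.79 log units; beyond the scatter) and shows that the high number of compound 1 goes with the fluoro group and not with but-1-en-1-yl, which the earlier pair, differing in two places at once, could not separate. Nothing available here accounts for either step.

The compounds shown leave open whether the double bond of but-1-en-1-yl matters, or the length of its chain, which a saturated butyl chain, a plain ethenyl group or a longer pent-1-en-1-yl chain on the same carbonyl carbon would address. They also leave open whether the step from fluoro to hydrogen is particular to fluoro or would extend to chloro or methoxy on that aromatic carbon.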